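Linker variation at the hydroxamate end of the series

The compounds below may be only part of what the source reports. "The series", "measured", "known", "first", "only" and "open" are said of these compounds alone.

Of the compounds shown here, three of the shared core have been measured in an assay on isolated protein for inhibition of protein deacetylase HDAC6 (Homo sapiens), read by fluorescence, with a stated time of 1 h, tested at 100 nM; on this read-out lower numbers stand for less inhibition and higher numbers for more inhibition at the one concentration tested (going by the name of the read-out). Compound 1 `O=C(/C=C/c1ccc(OCc2nc(C3CCN(Cc4ccccc4)CC3)no2)cc1)NO` gives 71%. Compound 2 `CCCN1CCC(c2noc(COc3ccc(CCC(=O)NO)cc3)n2)CC1` gives 13%. Compound 3 `O=C(CCc1ccc(OCc2nc(C3CCN(Cc4ccccc4)CC3)no2)cc1)NO` gives 22%, which is the second highest of the three numbers; its nearest neighbour is compound 2, within the scatter, and its furthest is compound 1, beyond the scatter. The step of a number 49 percentage points lower from compound 1 to compound 3 (beyond the scatter) was large, whereas the step of a number 9 percentage points higher from compound 2 to compound 3 (within the scatter) stayed within the scatter.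

Compound 4 `O=C(NO)c1ccc(OCc2nc(C3CCN(Cc4ccccc4)CC3)no2)cc1` has not yet been measured. It differs from compound 3 by hydroxycarbamoyl in place of 2-(hydroxycarbamoyl)ethyl on an aromatic carbon. Within the data shown here, only the step from compound 1 to compound 3 touches the same part of the molecule, and it showed that this end of the structure can move this assay strongly; no measured step shortens the chain in this way, so the direction is open. A step of uncertain sign but possibly large size is therefore expected, taken as a number 23 percentage points higher from compound 3 to compound 4 (beyond the scatter). For compound 4 a value of 45% is estimated, with a range from 10% to 85%.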

Compound 4, a percentage reported as inhibition, at one concentration (the size of the read-out at that concentration, not a potency): 66%
For compound 4 the middle estimate is 21 percentage points below the measured one; the measured number falls inside the stated range.
By their numbers in this assay, from the lowest: compounds 2 and 3 (each within the scatter of the next); then compounds 4 and 1 (each within the scatter of the next).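

In this assay, hydroxycarbamoyl in place of 2-(hydroxycarbamoyl)ethyl on the aromatic carbon gives a number 44 percentage points higher from compound 3 to compound 4 (beyond the scatter), so the low number of compound 3 does not extend to the shorter group at this position. Hydroxycarbamoyl in place of 2-(hydroxycarbamoyl)ethenyl gives a number 5 percentage points lower from compound 1 to compound 4 (within the scatter), so among the three groups tested here on this core, only 2-(hydroxycarbamoyl)ethyl stands apart, and compound 1 and compound 4 cannot be told apart. Nothing at hand explains why the saturated chain stands apart from the other two groups.

As far as these compounds go, whether a longer chain such as 3-(hydroxycarbamoyl)propyl follows compound 3 or compound 4 stays open, as does whether a carboxylic acid in place of the hydroxycarbamoyl end keeps any inhibition. From the compounds shown here alone, with one concentration only, any potency difference between compound 1 and compound 4 also stays open.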